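The source may hold more compounds than are shown below. What is called first, only, known or untested is meant among the compounds shown, and "the series" means these compounds.

Measured compounds:
- compound 1 `COc1ccc(N)c(C(=O)CCNC(=O)C2CCCCC2)c1` — 99.6%
- compound 2 `Nc1ccc(Cl)cc1C(=O)CCNC(=O)c1ccccc1` — "not determined" (no result reported)
- compound 3 `CC(=O)NCCC(=O)c1cc(Cl)ccc1N` — "not determined" (no result reported)

The account follows a single change made to compound 1. Going by the values given here, in a functional assay for inhibition of kynurenine 3-monooxygenase (Rattus norvegicus), tested at 1 mM (a lower number here means less inhibition, a higher number more inhibition at the concentration tested (going by the name of the read-out)), compound 1 gives 99.6%, which is the only number in this set; compound 2 and compound 3 have no result in this assay, so compound 1 stands alone and cannot be ranked against them. Its read-out sits close to the top of the scale, leaving little room for any rise.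

Compound 4 `COc1ccc(N)c(C(=O)CCNC(=O)C2CCCC2)c1` differs from compound 1 in one place: cyclopentyl in place of cyclohexyl on a carbonyl carbon. Among the compounds with values here, no step between two measured compounds is available to calibrate this change, so the expectation rests on compound 1 alone. Given that compound 1 gives 99.6%, the step is expected to be small and, if anything, downward, but not beyond the scatter of this assay. The expected step from compound 1 to compound 4 in this assay is a number 4.6 percentage points lower from compound 1 to compound 4 (within the scatter). Compound 4 is estimated to give 95% in this assay, within a range from 82% to 100%.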

Compound 4, a percentage reported as inhibition, at one concentration (the size of the read-out at that concentration, not a potency): 96.3%
Compound 4: middle estimate off by 1.3 percentage points, on the low side; the measured number falls inside the stated range.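

Going by these compounds alone, on a carbonyl carbon whose other neighbours are amide-type nitrogen, cyclopentyl in place of cyclohexyl gives, in this assay, a number 3.3 percentage points lower from compound 1 to compound 4 (within the scatter), the first step between two measured compounds in this set. At this position, then, a five-membered non-aromatic ring of carbon serves as well as the six-membered one in this read-out, and both compounds stay close to the top of the scale. Nothing at hand accounts for this result or ties it to any property of either ring.

What the compounds shown leave open is whether cyclopropyl, a straight butyl chain or a ring carrying an amine on that carbonyl carbon would keep the read-out this close to the top. As far as these compounds go, whether compound 1 and compound 4 differ in potency also stays open: a read-out at one concentration is not a potency.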